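The source may hold more compounds than are shown below. What is called first, only, known or untested is meant among the compounds shown, and "the series" means these compounds.

Measured compounds:
- compound 2, `CC(C)NC(=O)[C@H]1CC[C@@H](n2/c(=N/C(=O)c3ccc(F)cc3)[nH]c3ccc(CN4CC(C(C)(C)O)C4)cc32)CC1`, clearance in an in vivo ADME assay on the whole organism (plasma) for pharmacokinetics, with Rattus norvegicus as the target; a higher number here means faster removal of the compound, a lower number slower removal: 14.8 mL/min/kg
- compound 1, `CC(C)NC(=O)[C@H]1CC[C@@H](n2/c(=N/C(=O)c3ccc(F)cc3)[nH]c3ccc(CN4CCC[C@H]4C(C)(C)O)cc32)CC1`, result in this assay: "not determined" (no result reported)

Among the compounds with values here, compound 2 is the only compound here with a number in this assay; compound 1 shares the core but carries no reported result, so nothing can be said about how the two compare. Compound 3, `CC(C)NC(=O)[C@H]1CC[C@@H](n2/c(=N/C(=O)c3ccc(F)cc3)[nH]c3ccc(CN4CCNC(=O)C4)cc32)CC1`, has not yet been measured in this assay. It is built from compound 2 by a single exchange: 3-oxopiperazin-1-yl in place of 3-(1-hydroxy-1-methylethyl)azetidin-1-yl on a saturated chain carbon bound to an aromatic carbon. No measured pair with this kind of change exists among these compounds, so there is no step to lean on, only the one value of compound 2 and the change itself. With that basis, the step expected in this assay from a 1.0-fold higher number from compound 2 to compound 3 (0.01 log units; within the scatter) is small, in no fixed direction, and is not expected to exceed the usual scatter of such measurements. Accordingly, compound 3 is estimated at 15 mL/min/kg in this assay, with a range from 6 mL/min/kg to 35 mL/min/kg that reflects how little is known beyond the value of compound 2.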

Compound 3, clearance: 180 mL/min/kg
Compound 3: middle estimate off by 12-fold (1.08 log units), on the low side; the whole stated range lies below it.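

In this assay, putting 3-oxopiperazin-1-yl in place of 3-(1-hydroxy-1-methylethyl)azetidin-1-yl on a saturated chain carbon bound to an aromatic carbon gives a 12-fold higher number from compound 2 to compound 3 (1.09 log units; beyond the scatter). Within the data shown here, this is the first sign that this position matters for the read-out: with the shared core unchanged, exchanging this one group is enough to produce a large step. The step also does not follow the simple counts, since both groups have 1 hydrogen-bond donor, 2 hydrogen-bond acceptors and no net charge, and nothing available here explains the result.

The two groups differ in several ways at once, including ring size, the number of hetero atoms in the ring and the double bond outside aromatic rings, so this single step cannot show which difference goes with the higher number. A plain piperazin-1-yl group, which lacks the carbonyl of 3-oxopiperazin-1-yl, or a morpholin-4-yl group, with oxygen in place of one ring nitrogen, would help separate these features at the same position.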